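The source may hold more compounds than are shown below. What is called first, only, known or untested is meant among the compounds shown, and "the series" means these compounds.

In a functional assay on HCT-116 cells (Homo sapiens) for antiproliferative activity, read by MTT assay, with a stated time of 72 h (a lower number here means a stronger inhibitor, a higher number a weaker inhibitor), three compounds have been measured so far. Compound 1 `COc1cc(CCc2ccc(F)cc2)cc(OC)c1O` gives 1190 nM and holds the lowest number of the three, making it the strongest inhibitor among them. Compound 2 `COc1cc(CCc2cccc(F)c2)cc(OC)c1O` gives 7570 nM and compound 3 `COc1ccc(CCc2ccccc2Cl)cc1OC` gives 6160 nM in the same test. Both lie beyond the scatter from compound 1, while they do not separate from each other.

The next compound is compound 4 `COc1cc(CCc2ccc([N+](=O)[O-])cc2)cc(OC)c1O`, which keeps the core of compound 1 and changes a single group. It carries nitro in place of fluoro on an aromatic carbon, para to a large group (nitro in place of fluoro on an aromatic carbon). For the measured compounds named here, no two measured compounds differ in only one place, so the data give no direct measure of this exchange, and the expectation remains loose. Compound 1 at 1190 nM already sits at the low end of the numbers seen so far, so a rise is more likely than a further fall. The expected step of a 2.1-fold higher number from compound 1 to compound 4 (0.32 log units; beyond the scatter) is therefore a modest one towards weaker inhibition, and it may not clear the scatter. Compound 4 is estimated at 2500 nM within an expected range of 700 nM to 9000 nM when it is tested.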

Compound 4, half-maximal inhibitory concentration: 3160 nM
Compound 4: middle estimate off by 1.3-fold (0.10 log units), on the low side; the range from low to high includes it.
By their numbers in this assay, from the lowest: compound 1; then compounds 4, 3 and 2 (each within the scatter of the next, the first and the last beyond it).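

For the compounds shown here, this is the first pair of compounds that differ in only one place, so the exchange can now be read directly: in this assay, nitro in place of fluoro on an aromatic carbon, para to a large group, gives a 2.7-fold higher number from compound 1 to compound 4 (0.42 log units; beyond the scatter). The position therefore responds to the group it carries, and of the two groups seen there, fluoro goes with the stronger inhibition, while nitro weakens inhibition modestly without abolishing it. The change brings more heavy atoms and adds hydrogen-bond acceptors at this position, but nothing available measures what links either difference to the step, and no evidence bears on its cause.

A single pair cannot separate the part played by the added heavy atoms from that of the added acceptors, nor show whether the same exchange would give a step of like size elsewhere on the shared core. Going by these compounds, how an amine, a carboxylic acid or a methoxy group at this position would stand against fluoro and nitro also remains open.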